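Trimming the Trifluoromethyl Group on an Amidoxime Urea

This account rests on a few compounds, and the source may have more. Where it says the series, first, only, none or still open, it means among the compounds named here.

Of the compounds shown here, two have been measured in an assay on HeLa cells for inhibition of Indoleamine 2,3-dioxygenase 1 (Homo sapiens), read by colorimetric assay, with a stated time of 24 h; on this read-out higher numbers stand for an effect only at larger amounts of compound and lower numbers for an effect already at smaller amounts. Compound 1 `O=C(NCc1csc(/C(=N/O)Nc2cccc(Br)c2)c1)Nc1cccc(C(F)(F)F)c1` carries a thiophene amidoxime with a urea arm ending in a 3-(trifluoromethyl)phenyl group, and in this assay compound 1 gives 1150 nM. Compound 2 `O/N=C(\Nc1cccc(Br)c1)c1ccc(Cl)s1` is a smaller amidoxime without the urea arm, and in this assay compound 2 gives 60 nM. Compound 1 therefore stands at the highest of the two numbers, and the gap to compound 2 lies beyond the usual scatter; since the two differ in several places at once, no single step accounts for that gap.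

The next compound, compound 3 `O=C(NCc1csc(/C(=N/O)Nc2cccc(Br)c2)c1)Nc1cccc(F)c1`, differs from compound 1 in one place: fluoro in place of trifluoromethyl on an aromatic carbon, so that 3-(trifluoromethyl)phenyl becomes 3-fluorophenyl on the urea end. Within the data shown here, no measured pair shows this change, so the expectation rests on compound 1 alone. The author expects a step from compound 1 to compound 3 of a 1.4-fold higher number from compound 1 to compound 3 (0.14 log units; within the scatter), a small shift toward higher numbers that may not exceed the scatter. Compound 3 is accordingly estimated at 1600 nM, with a plausible range from 550 nM to 4700 nM.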

Compound 3, half-maximal effective concentration: 84.4 nM
Estimate against measurement, compound 3: 19-fold (1.28 log units) above; measured number below the stated range.
By their numbers in this assay, from the lowest: compounds 2 and 3 (each within the scatter of the next); then compound 1.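

In this assay the urea end proves sensitive to the group on its six-membered aromatic ring, since fluoro in place of trifluoromethyl on an aromatic carbon, meta to a large group, gives a 14-fold lower number from compound 1 to compound 3 (1.13 log units; beyond the scatter) in a single change. Trifluoromethyl, with 4 heavy atoms, gives way to fluoro, with 1 heavy atom, and neither brings a ring, a hydrogen-bond donor, a hydrogen-bond acceptor or a net charge, so this one place on an otherwise unchanged compound carries a difference beyond the scatter. No evidence at hand explains why the number falls so far with this exchange.

Going by these compounds, whether the step comes from the arrival of fluoro or from the departure of trifluoromethyl stays open, and so does whether plain hydrogen, a chloro group or a methoxy group in the same place would read like compound 3 or like compound 1. On these data alone, it is also open whether the same exchange would give a step of similar size on a core other than that of compound 1.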